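The source may report more compounds than this note shows. Statements on the series, on what has been measured and on what is new or still open speak of the compounds shown alone.

Values in a functional assay on MDA-MB-231 cells (Homo sapiens) for antiproliferative activity, read by MTT assay, with a stated time of 24 h; a higher number here means a weaker inhibitor, a lower number a stronger inhibitor:
- compound 1 `COc1ccccc1C(=O)NC(CC(=O)O)c1ccc(C(C)(C)C)cc1`: > 100000 nM
- compound 2 `O=C(O)CC(NC(=O)c1ccc(F)cc1)c1ccc(Cl)cc1Cl`: 58300 nM
- compound 3 `O=C(O)CC(NC(=O)c1ccc(C(F)(F)F)cc1)c1ccc(Cl)cc1Cl`: 39100 nM

The entry for compound 1 is a limit of the assay and not a number. That leaves compound 2 with a single numeric neighbour, compound 3, and the two lie within the scatter of each other.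

Compound 4 `O=C(O)CC(NC(=O)c1ccc(Cl)cc1Cl)c1ccc(Cl)cc1Cl` has not yet been measured. It carries 2,4-dichlorophenyl in place of 4-fluorophenyl on a carbonyl carbon. Going by the values given here, only one measured step bears on this, a 1.5-fold lower number from compound 2 to compound 3 (0.17 log units; within the scatter), which also alters the aromatic group on the carbonyl carbon and stays within the scatter. It is a single step with a different substituent, so it is only a modest guide. No step beyond the scatter is expected in this assay. The expected change is a 1.3-fold lower number from compound 2 to compound 4 (0.11 log units; within the scatter). For compound 4 the estimated value is 45000 nM, with an expected range of 20000 nM to 95000 nM.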

Compound 4, half-maximal inhibitory concentration: 49200 nM
Compound 4: the middle estimate sits 1.1-fold (0.04 log units) below what was measured, and the stated range covers the measured number.
By their numbers in this assay, from the lowest: compounds 3, 4 and 2 (each within the scatter of the next). At a limit, above all of these: compound 1.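

In this assay, 2,4-dichlorophenyl in place of 4-fluorophenyl on the carbonyl carbon gives a 1.2-fold lower number from compound 2 to compound 4 (0.07 log units; within the scatter). Until now a single replacement of the aromatic group at this position had been read; with a second, different one, both replacements of 4-fluorophenyl stay within the scatter, so this position has not yet given a step that can be told from noise. Compound 1 stands at a limit of the assay and not at a number, and it gives no step to read here: the limit of > 100000 nM in this assay, at which 1 of the 4 values shown sits.

Open, from the compounds shown here alone, is whether an amine or a hydroxyl on the phenyl at the carbonyl carbon, or a cyclohexyl in place of that phenyl, would move the number beyond the scatter. Also open, going by these compounds, is whether a change elsewhere on the shared core would do so.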